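Quinolin-2-yl in place of 3-bromophenyl on the dihydropyridine core

The source may hold more compounds than are shown below. What is called first, only, known or untested is meant among the compounds shown, and "the series" means these compounds.

The series rests on a shared core carrying an ester and an aryl group on a saturated ring carbon. Compound 1 `CC1=C(C(=O)OC2CCCCC2)C(c2ccc3c(c2)OCCO3)C2=C(CC(C)(C)CC2=O)N1` gives 12300 nM in an assay on HEK293 cells for inhibition of neurogenic locus notch homolog protein 1 (Homo sapiens), read by a luciferase reporter and resazurin assay, with a stated time of 16 h; on this read-out lower numbers stand for stronger inhibition and higher numbers for weaker inhibition. Compound 2 `CC1=C(C(=O)OCC2CCN(C(=O)OC(C)(C)C)CC2)[C@@H](c2cccc(Br)c2)C2=C(CC(C)(C)CC2=O)N1` gives 2590 nM. Compound 3 `CC1=C(C(=O)OCC2CCN(C(=O)OC(C)(C)C)CC2)C(c2cccc(Br)c2)C2=C(CC(C)(C)CC2=O)N1` gives 360 nM, the lowest of the three numbers, and its nearest neighbour is compound 2. Among the measured compounds shown here, the only step between compounds that differ in one place is a 7.2-fold lower number from compound 2 to compound 3 (0.86 log units; beyond the scatter); the difference between them is the fact that one of compounds 2 and 3 is drawn with a defined configuration and the other without, at the place where they differ. Compound 1 differs from compound 3 in two places, so its value stands on its own.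

Compound 4 `CC1=C(C(=O)OCC2CCN(C(=O)OC(C)(C)C)CC2)C(c2ccc3ccccc3n2)C2=C(CC(C)(C)CC2=O)N1` differs from compound 3 by quinolin-2-yl in place of 3-bromophenyl on a saturated ring carbon. For the measured compounds named here, no measured step touches the aryl group: the step from compound 2 to compound 3 concerns only the drawing of a stereocentre, and compound 1 changes both the aryl group and the ester at once. The expectation for compound 4 therefore rests on compound 3 alone, with wide uncertainty. Compound 4 is expected to give 800 nM, within a range from 150 nM to 5000 nM. The expected step is a 2.2-fold higher number from compound 3 to compound 4 (0.35 log units; beyond the scatter), a weakening that is estimated to lie close to the edge of the scatter.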

Compound 4, half-maximal inhibitory concentration: 330 nM
Beside the measured number, compound 4's estimate is 2.4-fold (0.38 log units) above it, and the stated range covers the measured number.
By their numbers in this assay, from the lowest: compounds 4 and 3 (each within the scatter of the next); then compound 2; then compound 1.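

In this assay, quinolin-2-yl in place of 3-bromophenyl on the saturated ring carbon gives a 1.1-fold lower number from compound 3 to compound 4 (0.04 log units; within the scatter), so compound 3 and compound 4 stand level. This is the only step shown that changes the aryl group alone, and it shows that this position tolerates the exchange of a bromine-bearing aryl group for quinolin-2-yl, with its added six-membered aromatic ring with 1 hetero atom and its hydrogen-bond acceptor, without a readable change in the number. Nothing available bears on why these two aryl groups give matching numbers.

Going by these compounds, it remains open whether the level would hold for other groups at this carbon, such as an unsubstituted phenyl, a pyridin-2-yl or a quinolin-2-yl carrying an amine or a carboxylic acid, and so how far the tolerance seen with compound 3 and compound 4 extends. Compound 4 is also drawn without a configuration at this carbon, which leaves open what each of its defined forms would give in this assay.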